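The compounds below may be only part of what the source reports. "The series", "measured", "known", "first", "only" and "open" are said of these compounds alone.

Measured compounds:
- compound 1, `CC(=O)SCCC(CCCCC(=O)O)SC(C)=O` — "not determined" (no result reported)
- compound 2, `O=C(CCCCC1CCSS1)Nc1ccc(OC(F)(F)F)cc1` — 38.2%
- compound 3, `O=C(CCCCC(S)CCS)Nc1ccccc1Cl` — "not determined" (no result reported)

Among the compounds with values here, of the three compounds with a reported entry in a functional assay on PC-3 cells (Homo sapiens) for inhibition, read by MTT assay, with a stated time of 24 h, tested at 10 ug/mL (on this read-out lower numbers stand for less inhibition of growth and higher numbers for more inhibition of growth at the one concentration tested), only compound 2 carries a number; compound 1 and compound 3 were not determined, so compound 2 stands alone as the single measured value. Compound 4, `O=C(CCCCC(S)CCS)Nc1ccc(OC(F)(F)F)cc1`, is not yet measured. It differs from compound 2 by one change: a group of 5 heavy atoms (3 carbon, 2 sulfur; no ring) in place of a group of 5 heavy atoms (3 carbon, 2 sulfur; one five-membered non-aromatic ring with 2 hetero atoms), on a saturated chain carbon, four bonds along the chain from a carbonyl carbon. Nothing measured shows how opening that ring to the free dithiol affects growth inhibition, since compound 3, which carries the same open chain, has no number. The step is therefore expected to be small, no larger than the scatter, in either direction. The expected result for compound 4 in this assay is 40%, between 20% and 60%, a step of a number 1.8 percentage points higher from compound 2 to compound 4 (within the scatter) expected from its parent.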

Compound 4, percent growth inhibition at one concentration: 42.5%
The estimate for compound 4 lay 2.5 percentage points below the measured number, and the stated range covers the measured number.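

In this assay there is a number 4.3 percentage points higher from compound 2 to compound 4 (within the scatter) on replacing the five-membered ring with the open 1,3-disulfanylpropyl group. Within the data shown here, at this place, four bonds along the chain from a carbonyl carbon, the closed ring and the open chain therefore cannot be told apart on this read-out, a comparison no earlier pair of numbers allowed. Nothing available here gives a reason for this result.

Still open, as far as these compounds go, is whether a carboxylic acid or an amine at this place, or a longer chain, would change growth inhibition.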